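Methoxy in place of hydroxy on compound 2

The source may report more compounds than this note shows. Statements on the series, on what has been measured and on what is new or still open speak of the compounds shown alone.

- compound 1 `CNC(=O)c1cc(C(=O)N[C@H]2CC[C@H](O)CC2)c([C@@H](C)c2cccc(Cl)c2)o1` gives 3.1 h in half-life
- compound 2 `CNC(=O)c1cc(C(=O)N[C@H]2CC[C@H](O)CC2)n([C@@H](C)c2ccccc2)n1` gives 9 h in half-life
- compound 3 `CNC(=O)c1cc(C(=O)N[C@H]2[C@@H]3COC[C@@H]32)c([C@@H](C)c2ccccc2)o1` gives 5 h in half-life

In an ADME assay on the whole organism (Canis lupus familiaris, strain Beagle) for metabolic stability, read by LC-MS, with a stated time of 7 h (a lower number here means that the compound disappears faster, a higher number that the compound lasts longer), compound 2 at 9 h stands beyond the scatter from compound 1 and within the scatter of compound 3.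

Compound 4 `CNC(=O)c1cc(C(=O)N[C@H]2CC[C@H](OC)CC2)n([C@@H](C)c2ccccc2)n1` differs from compound 2 in one place: methyl in place of hydrogen on an oxygen on a saturated carbon, which turns 4-hydroxycyclohexyl into 4-methoxycyclohexyl.

Going by the values given here, no measured pair shows this change alone. Among the compounds with values here, compound 1 and compound 3 each differ from compound 2 in more than one place, so the expectation has no direct precedent. The estimated step of a 1.4-fold lower number from compound 2 to compound 4 (0.14 log units; within the scatter) is expected to be small and downward, within the scatter of this assay and not beyond it.

For compound 4 the estimated half-life is 6.5 h with an expected range of 3 h to 13 h in this measurement.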

Compound 4, half-life: 4.1 h
Beside the measured number, compound 4's estimate is 1.6-fold (0.20 log units) above it; the range from low to high includes it.
By their numbers in this assay, from the lowest: compounds 1, 4, 3 and 2 (each within the scatter of the next, the first and the last beyond it).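

In this assay, methyl in place of hydrogen on the oxygen of the 4-hydroxycyclohexyl group gives a 2.2-fold lower number from compound 2 to compound 4 (0.34 log units; beyond the scatter), so this position responds to a single added methyl. Going by these compounds alone, this is the first pair that differs in one place, and it separates the hydroxy to methoxy change from the differences among the earlier compounds. Nothing available explains the step.

On these data alone, whether this step is specific to methyl or extends to other replacements of the hydrogen on this oxygen remains open; ethoxy, an acetate ester or an amine in place of the hydroxy would test that. As far as these compounds go, it is also open whether the hydroxy to methoxy change gives a similar step on the core of compound 1, which carries the same 4-hydroxycyclohexyl group.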